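A few compounds are considered here, and "the series" means these few. Any claim that something is new, unique, unknown or untested is made for them only; others in the source may bear on it.

Series notes. Going by the values given here, compound 1 `Cc1nc(-c2ccc(Cl)cc2)sc1C(=O)CSc1nc(-c2ccc(Cl)c(Cl)c2)c(C#N)c(=O)[nH]1` gives 93.9% in a functional assay on U-87MG ATCC cells for antiproliferative activity against U-87 MG (Homo sapiens), read by MTT assay, with a stated time of 48 h, tested at 50 uM (on this read-out lower numbers stand for a stronger effect and higher numbers for a weaker effect at the one concentration tested), the highest of the three numbers measured so far. Compound 2 `Cc1nc(-c2ccccc2)sc1C(=O)CSc1nc(-c2ccc(Cl)c(Cl)c2)c(C#N)c(=O)[nH]1` gives 75.3%, and compound 3 `COc1ccc(-c2nc(C)c(C(=O)CSc3nc(-c4ccc(Cl)c(Cl)c4)c(C#N)c(=O)[nH]3)s2)cc1` gives 78.4%. The steps of a number 18.6 percentage points lower from compound 1 to compound 2 (beyond the scatter) and a number 15.5 percentage points lower from compound 1 to compound 3 (beyond the scatter) both lie beyond the scatter, whereas a number 3.1 percentage points higher from compound 2 to compound 3 (within the scatter) does not. Compound 4 `Cc1nc(-c2ccc(Cl)cc2)sc1C(=O)CSc1nc(-c2ccc(Cl)cc2)c(C#N)c(=O)[nH]1` is not yet measured. Relative to compound 1 the change is hydrogen in place of chloro on an aromatic carbon, read one bond further out as 3,4-dichlorophenyl to 4-chlorophenyl. Among the compounds with values here, the only measured step of the same kind, hydrogen in place of chloro on an aromatic carbon, is a number 18.6 percentage points lower from compound 1 to compound 2 (beyond the scatter), though it sits on a different ring. A lowering of similar or smaller size is therefore expected for compound 4, as a number 9.9 percentage points lower from compound 1 to compound 4 (within the scatter). Compound 4 is estimated at 84%, with a range of 66% to 100%.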

Compound 4, a percentage reported as activity, at one concentration (the size of the read-out at that concentration, not a potency): 60%
Beside the measured number, compound 4's estimate is 24 percentage points above it; measured number outside the range, below it.
By their numbers in this assay, from the lowest: compound 4; then compounds 2 and 3 (each within the scatter of the next); then compound 1.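

In this assay, going from 3,4-dichlorophenyl to 4-chlorophenyl gives a number 33.9 percentage points lower from compound 1 to compound 4 (beyond the scatter), a large step towards a stronger effect, so the chloro at this position is not needed for the effect at the one concentration tested. Hydrogen in place of chloro on the other ring gives a number 18.6 percentage points lower from compound 1 to compound 2 (beyond the scatter), so the same change lowers the number at both sites of compound 1. No measurement shown here accounts for either step.

On these data alone, whether a fluoro group or an amine at this position would keep the lower number remains open. Also open, as far as these compounds go, is the effect of removing the remaining chloro from this ring.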